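Replacing the chain-end amine of compound 2 with a lactam

A few compounds are considered here, and "the series" means these few. Any claim that something is new, unique, unknown or untested is made for them only; others in the source may bear on it.

Measured compounds:
- compound 1, `COc1cc(OC)c2c(=O)cc(-c3ccc(OCCBr)cc3)oc2c1`: 20%
- compound 2, `COc1cc(OC)c2c(=O)cc(-c3ccc(OCCCN(C)C)cc3)oc2c1`: 86%

Within the data shown here, in a functional assay (Homo sapiens) for antiproliferative activity, read by resazurin assay, with a stated time of 48 h, tested at 20 uM (on this read-out higher numbers stand for a stronger effect at the one concentration tested and lower numbers for a weaker effect), compound 2 gives the higher of the two numbers, and the only step measured so far, a number 66 percentage points higher from compound 1 to compound 2 (beyond the scatter), shows that the group at the end of the chain can move this read-out by a great deal. Compound 3, `COc1cc(OC)c2c(=O)cc(-c3ccc(OCCN4CCCC4=O)cc3)oc2c1`, has not yet been measured. It differs from compound 2 by 2-oxopyrrolidin-1-yl in place of (dimethylamino)methyl on a saturated chain carbon, two bonds along the chain from an oxygen on an aromatic ring. Among the measured compounds shown here, no measured step covers this exact change; the one step available only tells that the chain end matters greatly, so a change beyond the scatter is plausible, and since compound 2 already stands highest, a fall is expected rather than a rise. The expected step is a number 41 percentage points lower from compound 2 to compound 3 (beyond the scatter). Compound 3 is therefore estimated at 45%, with a range from 15% to 80%.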

Compound 3, a percentage reported as inhibition, at one concentration (the size of the read-out at that concentration, not a potency): 33%
Compound 3: middle estimate off by 12 percentage points, on the high side; the range from low to high includes it.
By their numbers in this assay, from the lowest: compound 1; then compound 3; then compound 2.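

In this assay the 2-oxopyrrolidin-1-yl group loses most of what the dimethylamino end gave (a number 53 percentage points lower from compound 2 to compound 3 (beyond the scatter)), so a nitrogen in the group at the chain end is not enough on its own to keep the high number. Set against the bromo end, the same group gives only a small part of that gain (a number 13 percentage points higher from compound 1 to compound 3 (beyond the scatter)), which leaves compound 3 much nearer to compound 1 than to compound 2. The data offered here give no explanation for this fall.

The change also turns the 3-(dimethylamino)propoxy chain into a 2-(2-oxopyrrolidin-1-yl)ethoxy chain, so the shorter chain, the ring and the carbonyl all change together and cannot be told apart. A 3-(pyrrolidin-1-yl)propoxy chain, with the ring but no carbonyl, would help to separate them.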